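Halogen Exchange in a Pair of Antiproliferative Agents

The compounds below may be only part of what the source reports. "The series", "measured", "known", "first", "only" and "open" are said of these compounds alone.

compound 1 `NC1=C(C(=O)c2ccccc2)C(c2ccc(Br)cc2)N(CCCn2ccnc2)C1=O`: 149000 nM
compound 2 `O=C(C1=C(Nc2ccc(I)cc2)C(=O)N(CCCn2ccnc2)C1c1ccc(Br)cc1)c1ccccc1`: 12000 nM

For the measured compounds named here, in a functional assay on U2OS cells (Homo sapiens) for antiproliferative activity, read by MTT assay, with a stated time of 72 h (on this read-out lower numbers stand for stronger inhibition and higher numbers for weaker inhibition), compound 2 gives 12000 nM, the lower of the two numbers so far; the only measured step, a 12-fold lower number from compound 1 to compound 2 (1.09 log units; beyond the scatter), is large. Compound 3 `O=C(C1=C(Nc2ccc(Cl)cc2)C(=O)N(CCCn2ccnc2)C1c1ccc(Br)cc1)c1ccccc1` differs from compound 2 by chloro in place of iodo on an aromatic carbon. Going by the values given here, no measured step concerns a halogen exchange on that ring, so the large step from adding the whole 4-iodophenyl group is only loosely informative. A step within the usual scatter is expected, a 1.3-fold higher number from compound 2 to compound 3 (0.12 log units; within the scatter). Compound 3 is therefore estimated at 16000 nM, within a range of 6000 nM to 45000 nM.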

Compound 3, half-maximal inhibitory concentration: 22800 nM
The estimate for compound 3 lay 1.4-fold (0.15 log units) below the measured number; measured number inside the range.
By their numbers in this assay, from the lowest: compounds 2 and 3 (each within the scatter of the next); then compound 1.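

In this assay the exchange of iodo for chloro gives a 1.9-fold higher number from compound 2 to compound 3 (0.28 log units; within the scatter) and so does not separate the two halogens at this position. With a 6.5-fold lower number from compound 1 to compound 3 (0.82 log units; beyond the scatter) as its step, the 4-chlorophenyl group also gives a lower number than the hydrogen on the amine nitrogen, so the drop seen with 4-iodophenyl does not depend on iodine alone. Nothing measured here accounts for these numbers. Still open, going by these compounds, is how a plain phenyl, or a phenyl carrying a methoxy group or a carboxylic acid at this position, would compare with these two halogen-bearing rings.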